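Notes on the step from compound 3 to compound 4

This account rests on a few compounds, and the source may have more. Where it says the series, first, only, none or still open, it means among the compounds named here.

- Compound 1 `COc1ccccc1OS(=O)(=O)c1ccc(N2CCN(C)C2=O)cc1`: 26000 nM
- Compound 2 `COc1ccc(OS(=O)(=O)c2ccc(N3CCN(C)C3=O)cc2)cc1OC`: 12000 nM
- Compound 3 `CCN1CCN(c2ccc(S(=O)(=O)Oc3ccccc3OC)cc2)C1=O`: > 100000 nM, a limit and not a number

All values come from a functional assay on MCF7 cells (Homo sapiens) for antiproliferative activity, read by sulforhodamine B assay, with a stated time of 48 h; a lower number here means a stronger inhibitor, a higher number a weaker inhibitor. Compound 3 stands at the limit of > 100000 nM in this assay, at which 1 of the 3 values shown sits, so it offers only a limit as a starting point.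

Compound 4 `CCN1CCN(c2ccc(S(=O)(=O)Oc3cccc(I)c3)cc2)C1=O` carries 3-iodophenyl in place of 2-methoxyphenyl on an oxygen.

Among the compounds with values here, the one measured step here, an at least 3.8-fold higher number from compound 1 to compound 3 (0.58 log units; beyond the scatter), is a methyl in place of hydrogen on a saturated chain carbon bound to an amide-type nitrogen in a ring. It is a different change, so it gives no size for this exchange. Within the data shown here, no measured step covers the exchange on the oxygen, and the expectation is therefore loose.

Starting from a limit, only a move to a lower number could register as a step. Compound 2 at 12000 nM shows that numbers can be reached in this set. The estimated step is an at least 5.0-fold lower number from compound 3 to compound 4 (0.69 log units; beyond the scatter), with a real chance of no number at all. For compound 4 the estimate is 20000 nM, with an expected range of 3000 nM to 100000 nM.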

Compound 4, half-maximal inhibitory concentration: 1900 nM
Compound 4: the middle estimate sits 11-fold (1.02 log units) above what was measured; measured number below the stated range.
By their numbers in this assay, from the lowest: compound 4; then compound 2; then compound 1. At a limit, above all of these: compound 3.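

In this assay, the exchange on the oxygen bound to the sulfonyl sulfur has a large effect: an at least 52-fold lower number from compound 3 to compound 4 (1.72 log units; beyond the scatter), with 3-iodophenyl in place of 2-methoxyphenyl. The weak result of compound 3 is therefore not fixed by the ethyl group on the amide-type nitrogen, since compound 4 carries the same group and gives 1900 nM. Compound 3 gives a limit and not a number, so the printed size of this step is only a bound: the limit of > 100000 nM in this assay, at which 1 of the 4 values shown sits.

The exchange removes the methoxy group and brings in iodine at a different place on the phenyl ring, and the compounds shown cannot separate these two changes; 3-methoxyphenyl or 2-iodophenyl would do so. Also open, on these data alone, is whether 3-iodophenyl acts alike with a methyl group on the amide-type nitrogen.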